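Notes on the hydrazinyl thiadiazole series: compound 1 to compound 3

The source may report more compounds than this note shows. Statements on the series, on what has been measured and on what is new or still open speak of the compounds shown alone.

Measured so far:
- compound 1 `Cc1ccccc1-c1nnc(N(N)Cc2ccccc2)s1`: 27 mg/kg
- compound 2 `NN(Cc1ccccc1)c1nnc(-c2ccccc2Cl)s1`: 186 mg/kg

Compound 1 has the lowest of the two numbers recorded in a functional assay on the whole organism with Mus musculus as the target, in the maximal electroshock model, with a stated time of 1 h; on this read-out lower numbers stand for an effect already at smaller amounts and higher numbers for an effect only at larger amounts of compound. Going by the values given here, its nearest neighbour is compound 2, reached by a 6.9-fold higher number from compound 1 to compound 2 (0.84 log units; beyond the scatter); the only measured step in the set is therefore a change on the aromatic ring, not at the hydrazine.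

Compound 3 `Cc1ccccc1-c1nnc(N(Cc2ccccc2)N(C)C)s1` is not yet measured. It differs from compound 1 by dimethylamino in place of amino on a nitrogen on an aromatic ring, on a nitrogen on an aromatic ring whose other neighbours are an aromatic carbon and a saturated chain carbon. Among the compounds with values here, neither measured compound probes this position, so the step from compound 1 to compound 2 gives no direct guidance; it shows only that a single substituent change can move this assay by a modest amount.

Without a comparable precedent, compound 3 is expected to sit near compound 1 with a wide spread, the estimated step being a 1.5-fold higher number from compound 1 to compound 3 (0.17 log units; within the scatter). For compound 3 the estimate in this assay is 40 mg/kg, with a range from 14 mg/kg to 120 mg/kg.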

Compound 3, dose for half-maximal effect: > 200 mg/kg
Compound 3: only a limit was reported; the forecaster's own chance of this, stated with the estimate: 15%; middle value at least 5.0-fold (0.69 log units) from the limit.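

In this assay the hydrazine position proves sensitive: dimethylamino in place of amino on a nitrogen on an aromatic ring comes with an at least 7.4-fold higher number from compound 1 to compound 3 (0.86 log units; beyond the scatter) on an otherwise unchanged core. The entry for compound 3 is a limit and not a number: the limit of > 200 mg/kg in this assay, at which 1 of the 3 values shown sits. Going by these compounds alone, the only earlier step, chloro in place of methyl with a 6.9-fold higher number from compound 1 to compound 2 (0.84 log units; beyond the scatter), concerned the aromatic ring, so this result adds that the amino end of the molecule also carries a change beyond the scatter, with the full size of that change left unfixed by the limit.

The compounds shown leave open whether a single added methyl, as in methylamino, would already bring the same rise, or whether both methyl groups of dimethylamino are needed, and how an acetyl group on that same nitrogen would read. They also give no way to assign a cause to the step, and a true number for compound 3 would be needed to set its size against the step on the aromatic ring.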